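Ring fluorination steps in a sulfatase inhibitor series

A few compounds are considered here, and "the series" means these few. Any claim that something is new, unique, unknown or untested is made for them only; others in the source may bear on it.

Values measured so far in an assay on T47D cells for inhibition of Steryl-sulfatase (Homo sapiens), read by HPLC, with a stated time of 24 h; a higher number here means a weaker inhibitor, a lower number a stronger inhibitor:
compound 1, `Cc1ccccc1N(C)C(=O)c1ccc(-c2ccc(OS(N)(=O)=O)cc2)o1`: 28 nM
compound 2, `Cc1ccccc1N(C)C(=O)c1ccc(-c2ccc(OS(N)(=O)=O)c(F)c2)o1`: 17 nM
compound 3, `Cc1ccccc1N(C)C(=O)c1ccc(-c2ccc(OS(N)(=O)=O)cc2F)o1`: 12 nM

Compound 1 has the highest number of the three. Nearest to it is compound 2, a 1.6-fold lower number from compound 1 to compound 2 (0.22 log units; within the scatter), a step within the scatter; furthest is compound 3, a 2.3-fold lower number from compound 1 to compound 3 (0.37 log units; beyond the scatter), a modest step beyond the scatter. Compound 2 and compound 3 stand within the scatter of each other.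

Compound 4, `Cc1cccc(F)c1N(C)C(=O)c1ccc(-c2ccc(OS(N)(=O)=O)cc2)o1`, differs from compound 1 by fluoro in place of hydrogen on an aromatic carbon. The fluoro sits ortho to a large group and meta to a methyl group, so that the 2-methylphenyl of compound 1 becomes 2-fluoro-6-methylphenyl.

Both measured steps put fluoro on the other six-membered aromatic ring of the shared core, not on the ring changed here, so neither tests this position directly. Among the compounds with values here, their size is the only guide: one within the scatter, one modestly beyond it. For compound 4 in this assay a step of that small order toward a lower number is expected, a 1.3-fold lower number from compound 1 to compound 4 (0.10 log units; within the scatter), though a result within the scatter of compound 1 would not surprise. The estimate for compound 4 is 22 nM, with a range from 9 nM to 60 nM.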

Compound 4, half-maximal inhibitory concentration: 150 nM
For compound 4 the middle estimate is 6.8-fold (0.83 log units) below the measured one; measured number above the stated range.
By their numbers in this assay, from the lowest: compounds 3, 2 and 1 (each within the scatter of the next, the first and the last beyond it); then compound 4.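

In this assay the change from 2-methylphenyl to 2-fluoro-6-methylphenyl gives a 5.4-fold higher number from compound 1 to compound 4 (0.73 log units; beyond the scatter) and so runs the opposite way to a 2.3-fold lower number from compound 1 to compound 3 (0.37 log units; beyond the scatter) on the other six-membered aromatic ring of the shared core. The same replacement of hydrogen by fluoro therefore does not read across from one ring to the other, and on the 2-methylphenyl ring a single added fluorine, ortho to a large group and meta to a methyl group, is enough to move the number beyond the scatter in the unfavourable direction. No measurement at hand bears on why the number rises at this position.

Open, on these data alone, is whether chloro, methoxy or a nitrile at this place would raise the number as fluoro does, or whether the rise is particular to fluoro. Also open, as far as these compounds go, is whether the step depends on the methyl group, which a compound carrying this fluoro with hydrogen in place of that methyl would test, and whether it would recur on the core of compound 3.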